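The compounds below may be only part of what the source reports. "The series", "measured", "known", "first", "only" and "open" are said of these compounds alone.

Compound 1 `CS(=O)(=O)Oc1c(C(=O)NCc2ccc(F)cc2)nc(Br)c2cccnc12` gives, in a functional assay on MDA-MB-435 cells (Homo sapiens) for cytotoxicity, read by MTT assay, with a stated time of 72 h (on this read-out higher numbers stand for weaker inhibition and lower numbers for stronger inhibition), a value of > 20000 nM, which is a limit of the assay and not a number. Within the compounds shown it therefore stands at the weak end, at the limit described by the limit of > 20000 nM in this assay, at which 1 of the 3 values shown sits. Compound 2 `CN(C)c1ccc(CNC(=O)c2nc(Br)c3cccnc3c2N[C@H]2CC[C@H](N)CC2)cc1` gives 4000 nM in this assay. Compound 3 `N[C@H]1CC[C@H](Nc2c(C(=O)NC3CCCCC3)nc(Br)c3cccnc23)CC1` gives > 10000 nM in this assay, which is a limit of the assay; this is the limit described by the limit of > 10000 nM in this assay, at which 1 of the 3 values shown sits. Among the compounds with values here, the one measured step, an at least 2.5-fold higher number from compound 2 to compound 3 (0.39 log units; beyond the scatter), concerns the amide-type nitrogen and not the position changed here.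

Compound 4 `COC(=O)CNc1c(C(=O)NCc2ccc(F)cc2)nc(Br)c2cccnc12` differs from compound 1 by ((methoxycarbonyl)methyl)amino in place of (methylsulfonyl)oxy on an aromatic carbon. Within the data shown here, no measured step covers this exchange directly. Compounds 2 and 3 carry an amino substituent at an aromatic carbon of the shared core, and compound 2 reaches a measurable number there while compound 1 does not, so an amino group at that position may be compatible with some activity; compound 3 shows that the amide side also matters. On this basis compound 4 is expected to give 12000 nM in this assay, with a range from 3000 nM to 40000 nM, which corresponds to the expected step of an at least 1.6-fold lower number from compound 1 to compound 4 (0.22 log units; that floor lies within the scatter), while a limit rather than a number remains quite possible.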

Compound 4, half-maximal inhibitory concentration: 10000 nM
The estimate for compound 4 lay 1.2-fold (0.08 log units) above the measured number; the measured number falls inside the stated range.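

Within the data shown here, the result gives the first direct reading at this position: in this assay, ((methoxycarbonyl)methyl)amino in place of (methylsulfonyl)oxy gives an at least 2.0-fold lower number from compound 1 to compound 4 (0.30 log units; that floor lies within the scatter). With the amide side unchanged, compound 4 reaches a measurable number carrying an amino-linked chain on this aromatic carbon, but the step is only a floor, so its true size stays undetermined. The value of compound 1 is a limit of the assay and not a number: the limit of > 20000 nM in this assay, at which 1 of the 4 values shown sits.

The compounds shown do not separate the contribution of the linking nitrogen from that of the methyl ester at the end of the chain, and they leave open how a free carboxylic acid, a primary amine or a longer chain on this carbon would read. Compound 2 also carries an amino substituent on this carbon but differs from compound 4 in more than one place, so whether the amino substituent of compound 2 would give a lower number than ((methoxycarbonyl)methyl)amino with the same amide side remains unresolved.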